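A Fluorophenyl Amide Variant in a Weakly Active Series

The source may hold more compounds than are shown below. What is called first, only, known or untested is meant among the compounds shown, and "the series" means these compounds.

Two measured compounds share one core and differ only in the aryl group attached to the amide-type nitrogen. Compound 1 `O=C(CSc1nc(Nc2ccccc2)c2ccccc2n1)Nc1ccccc1Cl` gives 24800 nM in a functional assay on MGC-803 cells (Homo sapiens) for inhibition, read by MTT assay, with a stated time of 72 h; on this read-out lower numbers stand for stronger inhibition and higher numbers for weaker inhibition. Compound 2 `O=C(CSc1nc(Nc2ccccc2)c2ccccc2n1)Nc1cccc([N+](=O)[O-])c1` gives 28100 nM in this assay, the highest of the two numbers, and the step of a 1.1-fold higher number from compound 1 to compound 2 (0.05 log units; within the scatter) lies within the scatter. Compound 3 `O=C(CSc1nc(Nc2ccccc2)c2ccccc2n1)Nc1ccc(F)cc1` carries the change (4-fluorophenyl in place of 3-nitrophenyl on an amide-type nitrogen). Within the data shown here, the only measured step that bears on this change is a 1.1-fold higher number from compound 1 to compound 2 (0.05 log units; within the scatter), which shows that exchanging one aryl group for another on this nitrogen left the number unchanged within the scatter, so no step beyond the scatter is expected in this assay in either direction. Compound 3 is therefore expected to give 26000 nM, between 9000 nM and 75000 nM. The step this estimate means, a 1.1-fold lower number from compound 2 to compound 3 (0.03 log units; within the scatter), is expected to fall within the scatter.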

Compound 3, half-maximal inhibitory concentration: > 50000 nM
Compound 3 ended at the assay's limit; the forecaster's own chance of this, stated with the estimate: 10%; middle value at least 1.9-fold (0.28 log units) away from the limit.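

In this assay compound 3 ends at a limit of the assay rather than at a number, and it is the only compound shown to do so: the limit of > 50000 nM in this assay, at which 1 of the 3 values shown sits. This gives an at least 1.7-fold higher number from compound 2 to compound 3 (0.25 log units; that floor lies within the scatter) and an at least 2.0-fold higher number from compound 1 to compound 3 (0.30 log units; that floor lies within the scatter); these are floors only, so the true steps may be larger, but nothing shown places them beyond the scatter. What is new is that this amide-type nitrogen, where two aryl groups gave numbers, also carries an aryl group, 4-fluorophenyl, that gives only a limit.

From the compounds shown here alone, how far the true value of compound 3 lies past that limit remains open. Also open, going by these compounds, is what an unsubstituted phenyl, a 4-chlorophenyl or a benzyl group would give on this nitrogen, and so whether the fluorine itself counts for anything here.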